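Chloro for fluoro on the carbonyl-bound phenyl ring

The source may hold more compounds than are shown below. What is called first, only, known or untested is meant among the compounds shown, and "the series" means these compounds.

Two measured compounds share one core. Compound 1 `O=C(c1cccc(F)c1)N1CCCn2nc(COc3ccccc3)cc21` carries a 3-fluorophenyl on the carbonyl carbon; in a functional assay on HEK293 cells for positive allosteric modulation of metabotropic glutamate receptor 5 (Homo sapiens), read by calcium flux (a higher number here means a larger maximal response, a lower number a smaller maximal response), compound 1 gives 61%. Compound 2 `O=C(c1ccc(F)cc1)N1CCCn2nc(COc3ccccc3)cc21` carries a 4-fluorophenyl there instead, and in this assay compound 2 gives 63%. Going by the values given here, the single step so far, a number 2 percentage points higher from compound 1 to compound 2 (within the scatter), moves the fluoro around the ring without changing the halogen. On the numbers shown compound 2 stands highest of the two, but its gap to compound 1 lies within the scatter, so no order between the two can be read from it.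

Compound 3 `O=C(c1ccc(Cl)cc1)N1CCCn2nc(COc3ccccc3)cc21` is not yet measured. It differs from compound 2 by chloro in place of fluoro on an aromatic carbon. Among the compounds with values here, no measured step covers a fluoro-to-chloro exchange; the only available step, a number 2 percentage points higher from compound 1 to compound 2 (within the scatter), concerns position alone and was within the scatter, so it offers no direction for the halogen swap. With a single-atom change and nothing in the series beyond the scatter, the expected step is a number 2 percentage points higher from compound 2 to compound 3 (within the scatter), that is, none beyond the scatter. For compound 3 in this assay the estimate is 65%, with a range from 45% to 85%.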

Compound 3, largest response reached (reported as percent of maximum), in percent of the reference or control that the assay uses: 68%
Estimate against measurement, compound 3: 3 percentage points below; low and high end bracket the measured number.
By their numbers in this assay, from the lowest: compounds 1, 2 and 3 (each within the scatter of the next).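

Chloro in place of fluoro is the first exchange of the halogen itself at this position, and in this assay the two halogens cannot be told apart (a number 5 percentage points higher from compound 2 to compound 3 (within the scatter)). Going by these compounds alone, the broader replacement of 3-fluorophenyl by 4-chlorophenyl on the carbonyl carbon, which alters both the halogen and its place on the ring, also stays inside the usual variation (a number 7 percentage points higher from compound 1 to compound 3 (within the scatter)), so none of the three compounds can be ranked against another, and the position so far accepts either halogen without a readable difference in maximal response. Nothing available explains these numbers or links them to any property of the halogen.

Still open, on these data alone, is whether any group on this ring can shift the maximal response beyond the scatter, for instance bromo, methoxy, nitrile or trifluoromethyl in place of chloro, or an amine or a carboxylic acid on the same carbon. The series also leaves open whether chloro on the ring carbon held by the fluoro of compound 1 would read any differently from the 4-chlorophenyl of compound 3.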